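The compounds below may be only part of what the source reports. "The series", "measured", "known", "first", "only" and "open" are said of these compounds alone.

Measured so far in an ADME assay on J774.A1 cells (Mus musculus) for cytotoxicity, read by MTT assay, with a stated time of 72 h; a higher number here means that more compound is tolerated, a lower number that less compound is tolerated:
compound 1 `Clc1cccc(COC(CCn2ccnc2)c2ccco2)c1` gives 60200 nM;
compound 2 `Clc1ccc(Cl)c(COC(CCn2cncn2)c2ccco2)c1` gives 28900 nM.

Compound 2 stands at the lower of the two numbers, with compound 1 the nearer neighbour at a higher value, a gap that lies beyond the usual scatter. Going by the values given here, no pair of measured compounds differs in one place only, so no single structural step has a measured size here; the two values are all that can be read.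

Compound 3 `Clc1ccc(Cl)c(COC(CCn2ccnc2)c2ccco2)c1` is next to be measured. It differs from compound 2 as follows: 1H-imidazol-1-yl in place of 1H-1,2,4-triazol-1-yl on a saturated chain carbon, three bonds along the chain from an aromatic carbon and an oxygen on a saturated carbon. Compound 1 carries the same 1H-imidazol-1-yl group, but differs from compound 3 elsewhere as well, so its value is only a loose pointer. Of this step in this assay, a small change is expected, not clearly beyond the scatter, if anything toward a higher number. For compound 3 the estimate is 36000 nM, between 15000 nM and 85000 nM, which means an expected step of a 1.2-fold higher number from compound 2 to compound 3 (0.10 log units; within the scatter).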

Compound 3, half-maximal cytotoxic concentration: 37600 nM
For compound 3 the middle estimate is 1.0-fold (0.02 log units) below the measured one; measured number inside the range.
By their numbers in this assay, from the lowest: compounds 2, 3 and 1 (each within the scatter of the next, the first and the last beyond it).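

Going by these compounds alone, compound 3 supplies the first steps that change one place only. In this assay, 1H-imidazol-1-yl in place of 1H-1,2,4-triazol-1-yl on a saturated chain carbon gives a 1.3-fold higher number from compound 2 to compound 3 (0.11 log units; within the scatter) and chloro in place of hydrogen on an aromatic carbon gives a 1.6-fold lower number from compound 1 to compound 3 (0.20 log units; within the scatter); both steps lie within the scatter, so neither change has a resolved effect on the tolerated concentration here. Nothing available gives a reason for the size of either step.

On these data alone, it remains open whether a group of another kind at the same chain carbon, such as an open-chain amine or a carboxylic acid, would give a step beyond the scatter. A bromo or methoxy group in place of the added chloro is equally untested by the compounds shown, as is any longer chain carrying the 1H-imidazol-1-yl group.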